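A few compounds are considered here, and "the series" means these few. Any claim that something is new, unique, unknown or untested is made for them only; others in the source may bear on it.

Measured compounds:
- compound 1, `Cc1ccc(NC(=S)NC(=O)c2ccc(OCc3ccc(C(F)(F)F)cc3)cc2)cc1-c1nc2ccccc2[nH]1`: 17600 nM
- compound 2, `Cc1ccc(NC(=O)NC(=O)c2ccc(OCc3ccccc3)cc2)cc1-c1nc2ccccc2[nH]1`: 16400 nM

Compound 1 and compound 2 were both tested in a functional assay on HT-29 cells (Homo sapiens) for inhibition, read by MTT assay, with a stated time of 48 h; a lower number here means a stronger inhibitor, a higher number a weaker inhibitor. Compound 2 has the lowest of the two numbers, but compound 1 sits within the scatter of it, so the two values show no order between them. Compound 3, `Cc1ccc(NC(=O)NC(=O)c2ccc(OCc3ccc(C(F)(F)F)cc3)cc2)cc1-c1nc2ccccc2[nH]1`, has not yet been measured. It differs from compound 2 in one place: trifluoromethyl in place of hydrogen on an aromatic carbon. Going by the values given here, no step between two measured compounds of this set isolates this change, so the expectation rests on compound 2 alone, whose value in this assay is 16400 nM. The step from compound 2 to compound 3 is expected to be small, a 1.1-fold lower number from compound 2 to compound 3 (0.04 log units; within the scatter), in no clear direction beyond the scatter. Compound 3 is accordingly estimated at 15000 nM in this assay, with a range from 6000 nM to 38000 nM.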

Compound 3, half-maximal inhibitory concentration: 7830 nM
For compound 3 the middle estimate is 1.9-fold (0.28 log units) above the measured one; the measured number falls inside the stated range.
By their numbers in this assay, from the lowest: compound 3; then compounds 2 and 1 (each within the scatter of the next).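

In this assay the change of hydrogen to trifluoromethyl on an aromatic carbon, para to a large group, gives a 2.1-fold lower number from compound 2 to compound 3 (0.32 log units; beyond the scatter), a modest step that lies beyond the scatter. Compounds 1 and 2 differ in more than one place, so their values could not isolate this change; this pair shows that the position of the benzyloxy ring responds to substitution in this assay, although only by a modest amount. Nothing available explains why the number falls.

Going by these compounds, whether this step belongs to trifluoromethyl in particular remains open, since a chlorine atom, a methoxy group or a nitrile at the same place could give a similar number or a different one. On these data alone, how far a larger group such as a phenyl ring would be tolerated there also remains unknown.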